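Swapping an Oxazole for a Benzoyl on a Shared Core

The source may hold more compounds than are shown below. What is called first, only, known or untested is meant among the compounds shown, and "the series" means these compounds.

Compound 1, `O=C(Nc1cccc(Oc2nccc(C(F)(F)F)c2Cl)c1)C1CCCN(C(=O)c2cc(C(F)(F)F)cc(C(F)(F)F)c2)C1`, in an ADME assay on PC-3 cells (Homo sapiens) for cytotoxicity, read by WST assay, tested at 100 uM (on this read-out higher numbers stand for more inhibition at the one concentration tested (going by the name of the read-out) and lower numbers for less inhibition), gives 0%.
Compound 2, `O=C(Nc1cccc(Oc2ccccn2)c1)C1CCCN(C(=O)c2cc(C(F)(F)F)cc(C(F)(F)F)c2)C1`, in this assay gives 0%.
Compound 3, `O=C(Nc1cccc(-c2cnco2)c1)C1CCCN(C(=O)c2cc(C(F)(F)F)cc(C(F)(F)F)c2)C1`, in this assay gives 9%.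

All three share the same core and differ only in the group carried on one aromatic carbon. Compound 3 reads 9% in this assay. The step of a number 9 percentage points higher from compound 1 to compound 3 (within the scatter) and the step of a number 9 percentage points higher from compound 2 to compound 3 (within the scatter) both lie within the scatter, and so does the step of no change at the digits printed from compound 1 to compound 2 (within the scatter), so the three compounds are indistinguishable on this read-out: none of them shows meaningful inhibition at the single concentration tested.

Compound 4, `O=C(c1ccccc1)c1cccc(NC(=O)C2CCCN(C(=O)c3cc(C(F)(F)F)cc(C(F)(F)F)c3)C2)c1`, differs from compound 3 in one place: benzoyl in place of 1,3-oxazol-5-yl on an aromatic carbon. For the measured compounds named here, no measured step involves a benzoyl group, so there is no direct precedent. What the three measured steps do show is that exchanging the group at this position, whether a substituted pyridinyloxy, a plain pyridinyloxy or an oxazolyl, has left this assay within the scatter each time.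

On that basis compound 4 is expected to give 5% in this assay, with a range from 0% to 20%. The expected step of a number 4 percentage points lower from compound 3 to compound 4 (within the scatter) is estimated to stay within the scatter.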

Compound 4, a percentage reported as inhibition, at one concentration (the size of the read-out at that concentration, not a potency): 0%
Compound 4: middle estimate off by 5 percentage points, on the high side, within the range that was stated.
By their numbers in this assay, from the lowest: compounds 1, 2, 4 and 3 (each within the scatter of the next).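

The position now takes a benzoyl group, whose carbonyl links a six-membered aromatic ring of carbon only to this aromatic carbon, and in this assay benzoyl in place of 1,3-oxazol-5-yl gives a number 9 percentage points lower from compound 3 to compound 4 (within the scatter), in place of (pyridin-2-yl)oxy gives no change at the digits printed from compound 2 to compound 4 (within the scatter), and in place of (3-chloro-4-(trifluoromethyl)pyridin-2-yl)oxy gives no change at the digits printed from compound 1 to compound 4 (within the scatter). A carbonyl-linked ring therefore joins a directly attached ring and two oxygen-linked rings as a change that does not separate the compounds on this read-out, and across these four compounds none of the exchanges at this position moves the number beyond the scatter. Nothing available here gives a reason for this result.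

Still open, going by these compounds, is whether a group of a different kind on this aromatic carbon, such as an amine or a carboxylic acid, would give a number beyond the scatter of these four. Also open, on these data alone, is whether replacing the two trifluoromethyl groups elsewhere on the shared core with, for example, chlorine atoms would change the picture in this assay.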